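Holding a Tolerated Limit Across an Aryl Swap

The compounds below may be only part of what the source reports. "The series", "measured", "known", "first", "only" and "open" are said of these compounds alone.

Measured so far in an ADME assay on MDCK cells (Canis lupus familiaris) for cytotoxicity; a higher number here means that more compound is tolerated, a lower number that less compound is tolerated:
- Compound 1 `CC(=O)Nc1ccc2oc(-c3ccnc(C(=O)N4CCC5(CC4)CCN(C(c4ccccc4)c4nnn(C)n4)CC5)c3)nc2c1`: > 50000 nM (a limit of the assay)
- Compound 2 `CC(=O)Nc1ccc2oc(-c3ccnc(C(=O)N4CC5(CCN(C(c6ccccc6)c6nnn(C)n6)CC5)C4)c3)nc2c1`: 32100 nM
- Compound 3 `CC(=O)Nc1ccc2oc(-c3ccnc(C(=O)N4CCN(C(c5nnn(C)n5)c5ccccc5F)CC4)c3)nc2c1`: > 50000 nM (a limit of the assay)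

Compound 3 reads > 50000 nM. On these data alone, that reading is a limit and not a number, so its true position in this assay remains open. The set as a whole is marked by the limit of > 50000 nM in this assay, at which 2 of the 3 values shown sit. Only compound 2 gives an actual number, 32100 nM.

The step of interest leads from compound 3 to compound 4 `CC(=O)Nc1ccc2oc(-c3ccnc(C(=O)N4CCN(C(c5ccc(Cl)cc5)c5nnn(C)n5)CC4)c3)nc2c1`. It places 4-chlorophenyl in place of 2-fluorophenyl on a saturated chain carbon bound to an amine nitrogen in a ring and an aromatic carbon. Among the compounds with values here, no measured pair in the set isolates a change of this kind, so the expectation rests on the values alone. The result for compound 4 may well be reported as a limit again. Compound 2 at 32100 nM shows that a number can also appear. The estimated step of an at least 1.1-fold lower number from compound 3 to compound 4 (0.04 log units; that floor lies within the scatter) is expected to stay within the usual scatter, with no clear direction. Compound 4 is expected at 45000 nM, with an estimated range from 20000 nM to 50000 nM.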

Compound 4, half-maximal cytotoxic concentration: > 50000 nM
Compound 4 gave a limit, no number; the forecaster's own chance of this, stated with the estimate: 60%; middle value at least 1.1-fold (0.04 log units) from the limit.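

In this assay compound 4 reads > 50000 nM, a limit of the assay and not a number. Compound 3 also stands at a limit, so no step can be read between compound 3 and compound 4. Whether 4-chlorophenyl in place of 2-fluorophenyl shifts the true tolerated concentration stays open, with the set still marked by one limit: the limit of > 50000 nM in this assay, at which 3 of the 4 values shown sit.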